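A Methyl for a Methoxy on the Fluoro-Bearing Ring

The source may report more compounds than this note shows. Statements on the series, on what has been measured and on what is new or still open speak of the compounds shown alone.

Compound 3 `C=CC[C@H]1C[C@]2([C@@H](C)Cc3cc(OC)c(OC)cc3F)OCOC2=CC1=O` gives the lowest number of the three measured compounds in a functional assay on M14 cells (Homo sapiens) for antiproliferative activity, with a stated time of 72 h (a higher number here means a weaker inhibitor, a lower number a stronger inhibitor), at 14 nM. Compound 1 `C=CC[C@H]1C[C@]2([C@@H](C)Cc3ccc(OC)c(OC)c3)OCOC2=CC1=O` gives 110 nM, and compound 2 `C=CC[C@H]1C[C@]2([C@@H](C)Cc3ccc(OC)c(C)c3)OCOC2=CC1=O` gives 410 nM. The step of a 7.9-fold lower number from compound 1 to compound 3 (0.90 log units; beyond the scatter) came with fluoro in place of hydrogen on an aromatic carbon, and the step of a 3.7-fold higher number from compound 1 to compound 2 (0.57 log units; beyond the scatter) came with methyl in place of methoxy on an aromatic carbon.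

Compound 4 `C=CC[C@H]1C[C@]2([C@@H](C)Cc3cc(C)c(OC)cc3F)OCOC2=CC1=O` differs from compound 3 in one place: methyl in place of methoxy on an aromatic carbon. This is the same swap that separates compound 1 from compound 2, now made on the aromatic ring of compound 3, which also bears the fluoro group. Among the compounds with values here, only one measured step bears on it, a 3.7-fold higher number from compound 1 to compound 2 (0.57 log units; beyond the scatter), a modest rise beyond the scatter. Within the data shown here, nothing among the measured compounds shows whether the fluoro group alters the outcome of this swap, so a rise of similar size is expected for compound 4, and the estimated step is a 3.6-fold higher number from compound 3 to compound 4 (0.55 log units; beyond the scatter). Compound 4 is therefore expected to give about 50 nM in this assay, with a range from 15 nM to 160 nM.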

Compound 4, half-maximal inhibitory concentration: 230 nM
Beside the measured number, compound 4's estimate is 4.6-fold (0.66 log units) below it; the whole stated range lies below it.
By their numbers in this assay, from the lowest: compound 3; then compound 1; then compounds 4 and 2 (each within the scatter of the next).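

In this assay, methyl in place of methoxy, on the carbon para to a fluoro group, brings a 16-fold higher number from compound 3 to compound 4 (1.22 log units; beyond the scatter), so this swap has no fixed cost that carries over from one core to another: the same change on two cores in this assay, a 3.7-fold higher number (0.57 log units; beyond the scatter) from compound 1 to compound 2 and a 16-fold higher number (1.22 log units; beyond the scatter) from compound 3 to compound 4, 4.4-fold (0.64 log units) apart, beyond the scatter of two such steps. Read the other way round, the fluoro group matters much less once the methoxy has gone, bringing only a 1.8-fold lower number from compound 2 to compound 4 (0.25 log units; within the scatter), so its effect too depends on what else the ring carries: the same change on two cores in this assay, a 7.9-fold lower number (0.90 log units; beyond the scatter) from compound 1 to compound 3 and a 1.8-fold lower number (0.25 log units; within the scatter) from compound 2 to compound 4, 4.4-fold (0.64 log units) apart, beyond the scatter of two such steps. The two changes therefore do not simply add up on this ring, and the fluoro group and the methoxy count for most when they stand together, as in compound 3 at 14 nM.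

At this position the compounds shown compare only methoxy and methyl, so it remains open whether a hydroxyl, an ethoxy or an amine there would keep the low number of compound 3. Also open, on these data alone, is whether chloro in place of the fluoro group would show the same dependence on the methoxy.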